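The compounds below may be only part of what the source reports. "The series", "measured", "known", "first", "only" and "open" are said of these compounds alone.

In an ADME assay on microsomes from liver (Rattus norvegicus, strain Sprague-Dawley) for metabolic stability, read by HPLC, using NADPH, with stated times of 5 min and 60 min, tested at 10 uM (a lower number here means that the compound disappears faster, a higher number that the compound lasts longer), compound 1 `CC(C)(C)c1ccc(C(=O)NCc2ccc(NS(=O)(=O)C(F)(F)F)cc2Cl)cc1` gives 1.3 h and compound 2 `CC(C)(C)c1ccc(C(=O)NCc2ccc(NS(C)(=O)=O)cc2F)cc1` gives 0.483 h while compound 3 `CS(=O)(=O)Nc1ccc(CNC(=O)c2ccc(C(F)(F)F)cc2)c(Cl)c1` gives 2.43 h as its half-life. Compound 3 lies within the scatter of compound 1 and beyond the scatter above compound 2. Compound 4 `CCOc1ccc(C(=O)NCc2ccc(NS(C)(=O)=O)cc2Cl)cc1` carries ethoxy in place of trifluoromethyl on an aromatic carbon and otherwise matches compound 3. Among the measured compounds shown here, no measured pair isolates this change, so the data give no direct step size. A moderate drop in this assay is expected, with wide uncertainty, resting only on the span from compound 2 (0.483 h) to compound 3 (2.43 h). The estimated change is a 2.4-fold lower number from compound 3 to compound 4 (0.39 log units; beyond the scatter) on this basis. Compound 4 is expected at 1 h (estimated range 0.35 h to 2.6 h).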

Compound 4, half-life: 1.8 h
For compound 4 the middle estimate is 1.8-fold (0.26 log units) below the measured one; the measured number falls inside the stated range.
By their numbers in this assay, from the lowest: compound 2; then compounds 1, 4 and 3 (each within the scatter of the next).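

Ethoxy in place of trifluoromethyl on an aromatic carbon, para to a large group, gives a 1.4-fold lower number from compound 3 to compound 4 (0.13 log units; within the scatter) in this assay, the first step in the series that isolates this position. On this single pair, half-life does not separate the two groups, even though ethoxy brings a hydrogen-bond acceptor and trifluoromethyl brings none. No measured property bears on this result. Among the compounds shown here, only this one pair reads the position. As far as these compounds go, how an amine, a carboxylic acid or a chain longer than ethoxy would behave there in this assay remains open.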